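Swapping Fluoro for Methyl Beside the Ring Nitrogen

The compounds below may be only part of what the source reports. "The series", "measured", "known", "first", "only" and "open" are said of these compounds alone.

Of the compounds shown here, three have been measured in an assay on membranes from brain (strain Sprague-Dawley) for displacement of a labelled ligand from metabotropic glutamate receptor 5 (Rattus norvegicus), read by scintillation counting, with a stated time of 60 min; a lower number here means a stronger inhibitor, a higher number a weaker inhibitor. Compound 1 `N#Cc1cccc(C#Cc2cccc(C#N)n2)c1` gives 8.2 nM in this assay. Compound 2 `N#Cc1cccc(C#Cc2cc(F)cc(C(N)=O)c2)n1` reaches only the limit of this assay, > 10000 nM, so no number is known for it. Compound 3 `N#Cc1cc(F)cc(C#Cc2cccc(F)n2)c1` gives 41 nM, the higher of the two numbers shown, with compound 1 sitting well beyond the usual scatter at the lower end. Compound 4 `Cc1cccc(C#Cc2cc(F)cc(C#N)c2)n1` differs from compound 3 by methyl in place of fluoro on an aromatic carbon. Going by the values given here, no measured pair shows this same exchange, so its size is not yet known from data; a moderate drop in the number, somewhat beyond the scatter, is expected. Compound 4 is therefore estimated at 15 nM, with a likely range from 4 nM to 60 nM, which means an expected step of a 2.7-fold lower number from compound 3 to compound 4 (0.44 log units; beyond the scatter).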

Compound 4, inhibition constant: 0.67 nM
The estimate for compound 4 lay 22-fold (1.35 log units) above the measured number; the measured number lies below the stated range.
By their numbers in this assay, from the lowest: compound 4; then compound 1; then compound 3. At a limit, above all of these: compound 2.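

Methyl in place of fluoro next to the ring nitrogen brings a 61-fold lower number from compound 3 to compound 4 (1.79 log units; beyond the scatter) and so gives the first step between measured compounds that differ in one place. A single heavy atom at this position can therefore move the number a long way on its own. Nothing shown here accounts for the size of this step.

Going by these compounds, it remains open whether an ethyl chain, a methoxy group or an amine at this position would keep the low number of compound 4. On these data alone, whether the same exchange acts alike elsewhere also remains open, since this is a single pair.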